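Swapping the ether side group in a kinase activator

A few compounds are considered here, and "the series" means these few. Any claim that something is new, unique, unknown or untested is made for them only; others in the source may bear on it.

Measured so far:
compound 1 `Cc1cc(C(=O)O)ccc1CN1CCC[C@H](O[C@H](CO)c2ccccc2)[C@@H]1c1ccccc1` — > 200000 nM
compound 2 `Cc1cc(C(=O)O)ccc1CN1CCC[C@H](O[C@@H](CC(C)(C)O)c2cc(Cl)cc(Cl)c2)[C@@H]1c1ccccc1` — 8800 nM
compound 3 `Cc1cc(C(=O)O)ccc1CN1C(=O)CC[C@H](OCc2cc(Cl)cc(Cl)c2)[C@@H]1c1ccccc1` — > 200000 nM

Of the compounds shown here, three sharing one core have been tested in an assay on isolated protein for activation of cGMP-dependent protein kinase 1 (Homo sapiens), read by ADP-Glo, with stated times of 30 min and 2 h; a lower number here means that less compound is needed, a higher number that more compound is needed for the effect. Compound 1 reaches only the limit of this assay, > 200000 nM, so no number is known for it. Compound 3 likewise stops at a limit, > 200000 nM. Only compound 2, which carries a chlorine-bearing aromatic group with a hydroxyl on its ether side chain, gives a number, 8800 nM. Two of the three values therefore sit at the same limit (the limit of > 200000 nM in this assay, at which 2 of the 3 values shown sit), and compound 1 is among them.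

Compound 4 `Cc1cc(C(=O)O)ccc1CN1CCC[C@H](OC(c2cc(Cl)cc(Cl)c2)C(C)O)[C@@H]1c1ccccc1` has not yet been measured. It differs from compound 1 in one place: a group of 12 heavy atoms (9 carbon, 1 oxygen, 2 chlorine; one six-membered aromatic ring of carbon only) in place of a group of 9 heavy atoms (8 carbon, 1 oxygen; one six-membered aromatic ring of carbon only), on an oxygen on a saturated carbon. The new group resembles the side chain of compound 2 in carrying chlorines on the aromatic ring and a hydroxyl on the chain, though with a shorter chain and no defined stereocentre.

Since compound 1 sits at a limit, the size of the step to compound 4 cannot be given from a number, only a direction. Compound 4 is expected to come in below the limit, near 25000 nM, with a range from 6000 nM to 150000 nM. The step from compound 1 to compound 4 is therefore expected to be an improvement, roughly an at least 8.0-fold lower number from compound 1 to compound 4 (0.90 log units; beyond the scatter), though a further limit remains possible.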

Compound 4, half-maximal effective concentration: > 196000 nM
Compound 4: no number, only a limit; the forecaster's own chance of this, stated with the estimate: 35%; middle value at least 7.8-fold (0.89 log units) away from the limit.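

In this assay compound 1 and compound 4 both stop at a limit rather than a number, so the step between them cannot be read. The compounds shown leave open how much compound each would actually need for the effect, and which part of the ether side group decides whether a measurable number appears.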